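Three para-substituted ureas and an unsubstituted fourth

A few compounds are considered here, and "the series" means these few. Any claim that something is new, unique, unknown or untested is made for them only; others in the source may bear on it.

Measured so far:
Compound 1 `N#CC1CN1C(=O)Nc1ccc(F)cc1`: 2400 nM
Compound 2 `CCOC(=O)c1ccc(NC(=O)N2CC2C#N)cc1`: 2100 nM
Compound 3 `N#CC1CN1C(=O)Nc1ccc([N+](=O)[O-])cc1`: 3000 nM

In a functional assay on MCF7 cells (Homo sapiens) for inhibition (on this read-out lower numbers stand for stronger inhibition and higher numbers for weaker inhibition), compound 3 gives the highest of the three numbers, but its nearest neighbour is compound 1 a 1.3-fold higher number from compound 1 to compound 3 (0.10 log units; within the scatter) and its furthest is compound 2 a 1.4-fold higher number from compound 2 to compound 3 (0.15 log units; within the scatter), so all three sit within the scatter of one another. Compound 4 `N#CC1CN1C(=O)Nc1ccccc1` differs from compound 3 in one place: hydrogen in place of nitro on an aromatic carbon. Within the data shown here, two measured steps bear on this change, since both replace one group on that same aromatic carbon with another: a 1.3-fold higher number from compound 1 to compound 3 (0.10 log units; within the scatter) and a 1.4-fold higher number from compound 2 to compound 3 (0.15 log units; within the scatter). Neither moved the number beyond the scatter. Removing the nitro group altogether is a change of the same kind, so no step beyond the scatter is expected here either, in this assay. The expected step is a 1.2-fold lower number from compound 3 to compound 4 (0.08 log units; within the scatter). Compound 4 is therefore estimated at 2500 nM, with a range from 1200 nM to 5200 nM.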

Compound 4, half-maximal inhibitory concentration: 2600 nM
Estimate against measurement, compound 4: 1.0-fold (0.02 log units) below, within the range that was stated.
By their numbers in this assay, from the lowest: compounds 2, 1, 4 and 3 (each within the scatter of the next).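

Removing the group altogether leaves the number in this assay within the scatter of all three substituted ureas (a 1.2-fold lower number from compound 3 to compound 4 (0.06 log units; within the scatter)), (a 1.2-fold higher number from compound 2 to compound 4 (0.09 log units; within the scatter)) and (a 1.1-fold higher number from compound 1 to compound 4 (0.03 log units; within the scatter)). Among these compounds, the earlier compounds showed only that one group could replace another on this aromatic carbon, whereas these steps show that the nitro, ethoxycarbonyl and fluoro groups can each give way to plain hydrogen without a change beyond the scatter, so none of the three is needed to reach this level of inhibition. Nothing measured here explains this flat picture.

As far as these compounds go, what an amine, a carboxylic acid or a longer chain on this carbon would do stays open. From the compounds shown here alone, all four compounds also keep the nitrile and the rest of the shared core, so the effect of changing those parts remains open too.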